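Methyl to Hydrogen: Expected Cytotoxicity of Compound 4

A few compounds are considered here, and "the series" means these few. Any claim that something is new, unique, unknown or untested is made for them only; others in the source may bear on it.

Compound 1, `Cc1ccc2[nH]c(=O)c(-c3nc4cc([N+](=O)[O-])ccc4[nH]3)cc2c1`, gives in an ADME assay on L02 cells (Homo sapiens) for cytotoxicity, read by MTT assay, with a stated time of 48 h (on this read-out higher numbers stand for weaker inhibition and lower numbers for stronger inhibition), only a limit of the assay, > 100000 nM.
Compound 2, `O=c1[nH]c2ccccc2cc1-c1nc2cc([N+](=O)[O-])ccc2[nH]1`, gives in this assay only a limit of the assay, > 100000 nM.
Compound 3, `Cc1ccc2[nH]c(=O)c(-c3nc4cc(Cl)ccc4[nH]3)cc2c1`, gives in this assay only a limit of the assay, > 100000 nM.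

The three measured compounds share a core and differ from one another at a single position. From compound 1 to compound 2 the change is hydrogen in place of methyl on an aromatic carbon. The step that the two limits leave unreadable from compound 1 to compound 2 has no readable size, because both compounds sit at the limit of > 100000 nM in this assay, at which 3 of the 3 values shown sit. The cores of compound 1 and compound 3 differ by chloro in place of nitro on an aromatic carbon. The step that the two limits leave unreadable from compound 1 to compound 3 is likewise not readable, because both values sit at the limit of > 100000 nM in this assay, at which 3 of the 3 values shown sit.

Compound 4, `O=c1[nH]c2ccccc2cc1-c1nc2cc(Cl)ccc2[nH]1`, has not yet been measured in this assay. It stands to compound 3 as compound 2 stands to compound 1: the change is hydrogen in place of methyl on an aromatic carbon, and since the place is described in the same words in both cases, it is the same change. Among the compounds here this change occurs twice. Compound 4 is expected to move by about a step that the limit leaves unreadable from compound 3 to compound 4, an expectation that rests on compound 3 sitting at the limit of > 100000 nM in this assay, at which 3 of the 3 values shown sit, and on the same change from compound 1 to compound 2 leaving both at the limit of > 100000 nM in this assay, at which 3 of the 3 values shown sit. Compound 4 is therefore expected to give roughly 150000 nM, most likely again as a limit rather than a number, somewhere between 70000 nM and 400000 nM.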

Compound 4, half-maximal inhibitory concentration: > 100000 nM
Compound 4: a limit, no number (the forecaster's own chance of this, stated with the estimate: 85%); the middle value is on the limit's open side.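

No new step can be read from compound 4: its comparisons with compound 3 and with compound 2 both stay without a size, because all four compounds give the same limit rather than a number: the limit of > 100000 nM in this assay, at which 4 of the 4 values shown sit.

The compounds shown leave open whether hydrogen in place of methyl, or chloro in place of nitro, changes the result in this assay at all.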